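This account rests on a few compounds, and the source may have more. Where it says the series, first, only, none or still open, it means among the compounds named here.

Of the compounds shown here, two have so far been measured in a physicochemical assay for lipophilicity, read by HPLC, measured as octanol-water partition, at pH 7.4; a higher number here means a more lipophilic compound, a lower number a more polar compound. Compound 1 `NC(=O)[C@@H](CCC(F)(F)F)N(C[C@@H]1CCCOC1)S(=O)(=O)c1ccc(Cl)cc1` gives 3.7 in this assay. For the measured compounds named here, compound 2 `NC(=O)[C@@H](CCC(F)(F)F)N(C[C@@H]1CCO1)S(=O)(=O)c1ccc(Cl)cc1` gives 2.6 in this assay, the lower of the two numbers; the one measured step is a number 1.10 log units lower from compound 1 to compound 2 (beyond the scatter). Compound 3 `NC(=O)[C@@H](CCC(F)(F)F)N(C[C@H]1CCO1)S(=O)(=O)c1ccc(Cl)cc1` has not yet been measured in this assay. The change from compound 2 to compound 3 is this: the two compounds have the same atoms and bonds and differ only in configuration as drawn: 1 of 2 stereo elements differ; a stereocentre at a saturated ring carbon is drawn S in compound 2 and R in compound 3. Going by the values given here, no measured step bears on a change of configuration alone: the single step seen replaces oxan-3-yl with oxetan-2-yl and leaves every stereocentre as it was, so it offers no guide here. A change of configuration with every atom and bond kept gives no ground to expect a shift in this assay beyond the scatter. Compound 3 is therefore expected to give 2.6, between 2.3 and 2.9. The expected step is no change at the digits printed from compound 2 to compound 3 (within the scatter).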

Compound 3, distribution coefficient: 2.6
Compound 3: the middle estimate sits on the measured number at the digits printed; the measured number falls inside the stated range.
By their numbers in this assay, from the lowest: compounds 2 and 3 (each within the scatter of the next); then compound 1.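

In this assay the stereocentre at the saturated ring carbon of the oxetan-2-yl group can be inverted with no change at the digits printed from compound 2 to compound 3 (within the scatter), so this read-out does not separate the two drawn configurations. The comparison isolates configuration alone: the fact that compounds 2 and 3 differ only in the configuration as drawn. The earlier gain in polarity from the smaller ring now also holds for the other configuration, with a number 1.10 log units lower from compound 1 to compound 3 (beyond the scatter), so among these compounds that step does not depend on how this stereocentre is drawn.

The compounds shown leave open whether inverting the second stereocentre would be equally silent, and whether the two configurations would also match in a test other than this assay. They also leave open how far the number would move with an amine or a carboxylic acid in place of the oxetan-2-yl group.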